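Methoxy in Place of Methyl on the Sulfonyl Chain

This account rests on a few compounds, and the source may have more. Where it says the series, first, only, none or still open, it means among the compounds named here.

Compound 3 `CCCS(=O)(=O)N1CCN(c2ccc(OCC3CCN(C(=O)OC(C)C)CC3)cn2)CC1` gives 300 nM in a functional assay on CHO-K1 cells for agonist activity at Glucose-dependent insulinotropic receptor (Homo sapiens), read by a luciferase reporter, with a stated time of 5 h; on this read-out lower numbers stand for an effect already at smaller amounts and higher numbers for an effect only at larger amounts of compound. It stands level with compound 2 `CC(C)OC(=O)N1CCC(COc2ccc(N3CCN(S(=O)(=O)C(C)C)CC3)nc2)CC1`, which gives 300 nM in this assay, and the step of no change at the digits printed from compound 2 to compound 3 (within the scatter) lies within the scatter. Compound 1 `CC(C)OC(=O)N1CCC(COc2ccc(N3CCN(C(=O)N(C)C)CC3)nc2)CC1` sits at > 10000 nM in this assay, a limit of the assay rather than a number (the limit of > 10000 nM in this assay, at which 1 of the 3 values shown sits). The steps of an at least 33-fold lower number from compound 1 to compound 2 (1.52 log units; beyond the scatter) and an at least 33-fold lower number from compound 1 to compound 3 (1.52 log units; beyond the scatter) concern the group on the ring nitrogen, not the sulfonyl chain. Compound 4 `COCCS(=O)(=O)N1CCN(c2ccc(OCC3CCN(C(=O)OC(C)C)CC3)cn2)CC1` differs from compound 3 by methoxy in place of methyl on a saturated chain carbon, two bonds along the chain from a sulfonyl sulfur. For the measured compounds named here, the only measured step that alters the sulfonyl chain, compound 2 to compound 3, stayed within the scatter; no measured step bears on a methoxy there. Compound 4 is therefore expected to show a 1.3-fold higher number from compound 3 to compound 4 (0.12 log units; within the scatter), no change beyond the scatter. The value of compound 4 in this assay is estimated at 400 nM, between 150 nM and 1100 nM.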

Compound 4, half-maximal effective concentration: 300 nM
Beside the measured number, compound 4's estimate is 1.3-fold (0.12 log units) above it, and the stated range covers the measured number.
By their numbers in this assay, from the lowest: compounds 2, 3 and 4 (each within the scatter of the next). At a limit, above all of these: compound 1.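

In this assay, the methoxy on a saturated chain carbon, two bonds along the chain from a sulfonyl sulfur, gives no change at the digits printed from compound 3 to compound 4 (within the scatter), and 2-methoxyethyl in place of isopropyl gives no change at the digits printed from compound 2 to compound 4 (within the scatter). The sulfonyl chain therefore takes a hydrogen-bond acceptor, which the earlier chains lacked, with no step beyond the scatter. (2-Methoxyethyl)sulfonyl in place of dimethylcarbamoyl gives an at least 33-fold lower number from compound 1 to compound 4 (1.52 log units; beyond the scatter), a step that starts from a limit of the assay: the limit of > 10000 nM in this assay, at which 1 of the 4 values shown sits.

As far as these compounds go, whether an amine, a carboxylic acid or a longer chain in place of the methoxy would move the number beyond the scatter stays open.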